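A few compounds are considered here, and "the series" means these few. Any claim that something is new, unique, unknown or untested is made for them only; others in the source may bear on it.

Measured compounds and their values:
- compound 1, `CC(C)(C)c1ccc(C(=O)NCc2ccc(N)cc2Cl)cc1`, gives 46 nM in an assay on HeLa cells with Bile acid receptor (Homo sapiens) as the target, read by a luciferase reporter, with a stated time of 24 h; on this read-out lower numbers stand for an effect already at smaller amounts and higher numbers for an effect only at larger amounts of compound
- compound 2, `CSc1ccc(CNC(=O)c2ccc(C(C)(C)C)cc2)cc1`, gives 100 nM in this assay
- compound 3, `Cc1cc(CNC(=O)c2ccc(C(C)(C)C)cc2)ccc1C(=O)O`, gives 160 nM in this assay

Among these three numbers, compound 2 stands second highest. Its nearest neighbour is compound 3, whose number is higher but within the scatter, so the two cannot be told apart. Compound 1 lies furthest away, with a lower number that sits beyond the scatter.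

The next compound, compound 4, `CC(C)(C)c1ccc(C(=O)NCc2ccc(CCC(=O)O)cc2)cc1`, has not yet been measured in this assay. It is related to compound 2 by a single change: 2-carboxyethyl in place of methylsulfanyl on an aromatic carbon. Within the data shown here, this is the only change between the two structures; the rest of the shared core, with its tert-butyl-bearing amide, is kept.

Among the measured compounds shown here, no measured pair with a single difference is available to calibrate this step. What the data do offer is compound 3, which carries a carboxylic acid on the same ring and gives 160 nM, a number indistinguishable from that of compound 2. On that basis the step from compound 2 to compound 4 is expected to be small, a 1.5-fold higher number from compound 2 to compound 4 (0.18 log units; within the scatter), and not beyond the scatter in either direction. Compound 4 is therefore estimated at 150 nM, with a plausible range from 50 nM to 450 nM.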

Compound 4, half-maximal effective concentration: 350 nM
Estimate against measurement, compound 4: 2.3-fold (0.37 log units) below; low and high end bracket the measured number.
By their numbers in this assay, from the lowest: compound 1; then compounds 2 and 3 (each within the scatter of the next); then compound 4.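

In this assay, among these compounds, the exchange of methylsulfanyl for 2-carboxyethyl, on an aromatic carbon para to a large group, gives a 3.5-fold higher number from compound 2 to compound 4 (0.54 log units; beyond the scatter) and so provides the first reading of a single change. Among the compounds shown here, the step is modest but lies beyond the scatter, which shows that this position is not indifferent to the change, something the earlier compounds could not show, as no two of them differed in one place only. The entering chain is larger than methylsulfanyl and adds a hydrogen-bond donor, but no available evidence explains the higher number.

The compounds shown leave open whether the step follows from the carboxylic acid at the end of the chain or from the chain itself, a question that a plain propyl chain or the methyl ester of the same chain at this position would address. They also leave open how the number responds to chain length, for instance with a longer chain ending in a carboxylic acid, and whether a hydroxyl group here would be tolerated.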